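This account rests on a few compounds, and the source may have more. Where it says the series, first, only, none or still open, it means among the compounds named here.

Of the compounds shown here, three built on one shared core have been measured in an ADME assay on microsomes from liver (Homo sapiens) for metabolic stability, read by LC-MS, using NADPH, with stated times of 10 min and 45 min, tested at 1 uM; on this read-out higher numbers stand for fast clearance and lower numbers for slow clearance. Compound 1 `Cc1cc(C)c(CN2CCc3c(Cl)cc([C@H](CO)[C@H]4CCOC4)c(Cl)c3C2=O)c(=O)[nH]1` gives 21.3 uL/min. Compound 2 `COc1cc(C)[nH]c(=O)c1CN1CCc2c(Cl)cc(-c3c(C)noc3C)c(Cl)c2C1=O` gives 70 uL/min, the higher of the two single numbers, and the gap to compound 1 is wider than the usual scatter. Compound 3 `COC(c1cc(Cl)c2c(c1Cl)C(=O)N(Cc1c(C)cc(C)[nH]c1=O)CC2)C1CCOCC1` has been run more than once; its entries, (the several entries of compound 3 in this assay, 130 uL/min; 129 uL/min (2 entries)), agree closely with each other and stand as the fastest-cleared member of the three, since compound 3 gives 130 uL/min; 129 uL/min (2 entries).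

Compound 4 `COc1cc(C)[nH]c(=O)c1CN1CCc2c(Cl)cc([C@H](O)C3COC3)c(Cl)c2C1=O` is the next compound to be measured in this assay. It differs from compound 2 in one place: a group of 6 heavy atoms (4 carbon, 2 oxygen; one four-membered non-aromatic ring with 1 hetero atom) in place of a group of 7 heavy atoms (5 carbon, 1 nitrogen, 1 oxygen; one five-membered aromatic ring with 2 hetero atoms), on an aromatic carbon. The new group sits on an aromatic carbon of the six-membered carbon-only ring, ortho to a chloro group and meta to the other chloro group.

Against this background, compound 4 is expected to clear more slowly than compound 2, with the step of a 2.2-fold lower number from compound 2 to compound 4 (0.34 log units; beyond the scatter) going beyond the scatter, partly because compound 1, which also carries an alcohol-bearing side chain, gives 21.3 uL/min. The estimate for compound 4 is 32 uL/min, within a range from 14 uL/min to 75 uL/min.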

Compound 4, intrinsic clearance in a liver preparation (reported as CLH), per the amount of preparation that the assay uses in the liver assay: < 8 uL/min
Compound 4 gave a limit, no number; the forecaster's own chance of this, stated with the estimate: 5%; at least 4.0-fold (0.60 log units) between middle value and limit.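

In the liver assay, placing the new group with its four-membered ring on this aromatic carbon, in place of 3,5-dimethyl-1,2-oxazol-4-yl, gives an at least 8.7-fold lower number from compound 2 to compound 4 (0.94 log units; beyond the scatter), the first single-place step shown and evidence that clearance is highly sensitive to this position. The result for compound 4 is a limit, not a number, and the only one among the compounds shown: the limit of < 8 uL/min in the liver assay, at which 1 of the 4 values shown sits. In a physicochemical assay for solubility, measured as kinetic solubility (on this read-out higher numbers stand for higher solubility and lower numbers for lower solubility), compound 2 gives 384000 nM and compound 4 gives 234000 nM, two values within the scatter of each other.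

From the compounds shown here alone, the full size of the step remains open, as does which feature of the entering group goes with it. Also open, going by these compounds, is how an amine, a carboxylic acid or a longer chain on this aromatic carbon would compare in either assay.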